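Extending the saturated chain of compound 2

A few compounds are considered here, and "the series" means these few. Any claim that something is new, unique, unknown or untested is made for them only; others in the source may bear on it.

Measured so far:
compound 1, `Cc1nc(N2CCC2)nc(OC2CCC2)c1O`, 98%
compound 2, `CCCCCCCCCCCCCCc1nc(N2CCC2)nc(OC2CCC2)c1O`, 102%

Both numbers come from a functional assay on cells (Lymphocyte, Homo sapiens), read by a luciferase reporter and ATP content, with a stated time of 48 h, tested at 5 uM; a higher number here means a weaker effect of the compound at the concentration tested, a lower number a stronger effect. Compound 1 gives 98% and compound 2 gives 102%; the two read within the scatter of each other, so neither shows an effect at the concentration tested, and compound 2 cannot be set apart from compound 1 on these numbers. Compound 3, `CCCCCCCCCCCCCCCCc1nc(N2CCC2)nc(OC2CCC2)c1O`, remains to be measured in this assay. It differs from compound 2 by ethyl in place of hydrogen on a saturated chain carbon, ten or more bonds along the chain from an aromatic carbon. For the measured compounds named here, no step between measured compounds is available, so the expectation rests on compound 1 and compound 2 alone, both at the level of no effect. Compound 3 is expected to stay at that level, with the step of a number 2 percentage points lower from compound 2 to compound 3 (within the scatter) expected to be none beyond the scatter. Compound 3 is estimated at 100%, in the range 88% to 112%.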

Compound 3, a percentage reported as activity, at one concentration (the size of the read-out at that concentration, not a potency): 114%
Compound 3: middle estimate off by 14 percentage points, on the low side; the measured number lies above the stated range.
By their numbers in this assay, from the lowest: compounds 1 and 2 (each within the scatter of the next); then compound 3.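

In this assay, ethyl in place of hydrogen on a saturated chain carbon, ten or more bonds along the chain from an aromatic carbon, gives a number 12 percentage points higher from compound 2 to compound 3 (beyond the scatter). For the compounds shown here, a change this far out along the chain is therefore not silent: it moves the reading towards a weaker effect, and this is the only step that can be read. No measurement on hand bears on why the number moves at this position.

From the compounds shown here alone, whether a longer chain would shift the number further in the same direction remains open, since a single step does not establish a trend. Also open, going by these compounds, is whether an amine or a carboxylic acid at the chain end would bring the number down to a clear effect at the concentration tested.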